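The compounds below may be only part of what the source reports. "The series", "measured", "known", "first", "only" and "open" are said of these compounds alone.

Of the compounds shown here, three have been measured in a functional assay on Bel-7402 cells (Homo sapiens) for antiproliferative activity, read by sulforhodamine B assay, tested at 100 ug/mL; a lower number here means less inhibition, a higher number more inhibition at the concentration tested (going by the name of the read-out). Compound 1 `O=C1CCCCCC1S(=O)(=O)c1ccc(Cl)c(Cl)c1` gives 4.03%, and compound 2 `Cc1ccc(NS(=O)(=O)C2CCCCC2=O)c(C)c1` gives 0.52%. Compound 3 `O=C1CCCCC1S(=O)(=O)Nc1ccccc1Br` gives 22.1%, the highest of the three numbers; compound 1 lies nearest to it and compound 2 furthest, both gaps beyond the scatter. Compound 4 `O=C1CCCCC1S(=O)(=O)Nc1ccccc1Cl` is not yet measured. It differs from compound 3 in one place: chloro in place of bromo on an aromatic carbon. Going by the values given here, no step between two measured compounds matches this change, so the expectation rests on compound 3 alone. A change of this kind is expected to stay within the scatter in this assay, with no clear direction. Compound 4 is therefore estimated at 18%, within 5% to 35%. The expected step is a number 4.1 percentage points lower from compound 3 to compound 4 (within the scatter).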

Compound 4, a percentage reported as inhibition, at one concentration (the size of the read-out at that concentration, not a potency): 1.98%
Estimate against measurement, compound 4: 16 percentage points above; measured number outside the range, below it.
By their numbers in this assay, from the lowest: compounds 2, 4 and 1 (each within the scatter of the next); then compound 3.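

Chloro in place of bromo on an aromatic carbon, ortho to a large group, gives the first single-place step of the series in this assay: a number 20.1 percentage points lower from compound 3 to compound 4 (beyond the scatter). The inhibition of compound 3 is therefore not kept when chloro takes the place of bromo at this position. No measurement at hand explains this step.

On these data alone, it remains open whether an iodo, a methyl or a methoxy at this position would keep the inhibition of compound 3. One step also leaves open whether this halogen change would act the same way on another core.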